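The source may report more compounds than this note shows. Statements on the series, on what has been measured and on what is new or still open speak of the compounds shown alone.

In a functional assay on MCF7 cells (Homo sapiens) for inhibition, read by colorimetric assay and MTT assay, with a stated time of 72 h (a higher number here means a weaker inhibitor, a lower number a stronger inhibitor), compound 1 (`CCCCOc1ncc(-c2ccccc2OC)n1C`) gives 55000 nM. Compound 2 (`COc1ccccc1-c1cnc(OC)n1C`) reaches only a limit of the assay, > 100000 nM. Compound 3 (`C=CCCCCOc1ncc(-c2ccccc2OC)n1C`) gives 5000 nM, the lowest number among these three and the only one besides that of compound 1 that is not a limit.

Compound 4 (`C=CCCCCOc1ncc(-c2cc(C(C)C)ccc2OC)n1C`) keeps the structure of compound 3 except for isopropyl in place of hydrogen on an aromatic carbon of a six-membered aromatic ring of carbon only, meta to a large group and para to a methoxy group: isopropyl in place of hydrogen on an aromatic carbon.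

All three measured steps change the chain bound to the oxygen. Two are large, an 11-fold lower number from compound 1 to compound 3 (1.04 log units; beyond the scatter) and an at least 20-fold lower number from compound 2 to compound 3 (1.30 log units; beyond the scatter), while the third is an at least 1.8-fold higher number from compound 1 to compound 2 (0.25 log units; that floor lies within the scatter). Going by the values given here, none changes an aromatic carbon, so their sizes do not carry over to this step, and the data hold no direct precedent for it. Among the compounds with values here, they show only that one change elsewhere in compound 3 can move the number widely, as in an 11-fold lower number from compound 1 to compound 3 (1.04 log units; beyond the scatter). In this assay, no step beyond the scatter is therefore the central expectation, with a slight lean towards a lower number and wide uncertainty in either direction. The estimated change is a 1.4-fold lower number from compound 3 to compound 4 (0.15 log units; within the scatter). For compound 4 the estimated value is 3500 nM, with an expected range of 1000 nM to 12000 nM.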

Compound 4, half-maximal inhibitory concentration: 18000 nM
The estimate for compound 4 lay 5.1-fold (0.71 log units) below the measured number; the measured number lies above the stated range.
By their numbers in this assay, from the lowest: compound 3; then compound 4; then compound 1. At a limit, above all of these: compound 2.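

In this assay, the step of a 3.6-fold higher number from compound 3 to compound 4 (0.56 log units; beyond the scatter) is the first change shown outside the chain bound to the oxygen, and it shows that this aromatic carbon, meta to a large group and para to a methoxy group, is not indifferent to substitution. Added carbon therefore does not lower the number wherever it is placed: vinyl in place of hydrogen on the chain gave an 11-fold lower number from compound 1 to compound 3 (1.04 log units; beyond the scatter) and ran the other way, at a larger size than the isopropyl step. The data shown carry no measurement that explains the rise on this aromatic carbon.

Open, from the compounds shown here alone, is whether a methyl, a chlorine, an amine or a carboxylic acid on this aromatic carbon would move the number in the same direction as isopropyl, or whether the rise is particular to isopropyl. Going by these compounds alone, equally open is whether isopropyl here would give a step of similar size with the chain of compound 1, or with a longer chain on the oxygen than the one in compound 3.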